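Swapping the aryl group on a sulfonamide nitrogen

The compounds below may be only part of what the source reports. "The series", "measured", "known", "first", "only" and "open" are said of these compounds alone.

Three measured compounds share one core and differ only in the aryl group on the sulfonamide nitrogen. In a functional assay on HT-29 cells (Homo sapiens) for antiproliferative activity, read by sulforhodamine B assay, with a stated time of 48 h (a lower number here means a stronger inhibitor, a higher number a weaker inhibitor), compound 3 `Cc1cc(C)cc(NS(=O)(=O)c2ccc(N3CCNC3=O)cc2)c1` gives 82 nM, the lowest of the two numbers available. Its nearest neighbour is compound 1 `CCc1ccc(NS(=O)(=O)c2ccc(N3CCNC3=O)cc2)cc1`, which in this assay gives 660 nM; the step of an 8.0-fold lower number from compound 1 to compound 3 (0.91 log units; beyond the scatter) lies beyond the scatter. Compound 2 `CC(C)(C)c1ccc(NS(=O)(=O)c2ccc(N3CCNC3=O)cc2)cc1` reaches only a limit in this assay, > 1000 nM. That single limit is the limit of > 1000 nM in this assay, at which 1 of the 3 values shown sits. The step of an at least 1.5-fold higher number from compound 1 to compound 2 (0.18 log units; that floor lies within the scatter) does not clear the scatter.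

Compound 4 `O=C1NCCN1c1ccc(S(=O)(=O)Nc2ccc(F)cc2)cc1` is not yet measured. 4-fluorophenyl in place of 3,5-dimethylphenyl on a sulfonamide nitrogen Both measured steps concern the group on this nitrogen. The gain from compound 1 to compound 3 arrived together with the 3,5-dimethylphenyl, and compound 4 gives that group up for 4-fluorophenyl, a change back toward the kind of group carried by compound 1. Going by the values given here, since no measured compound carries 4-fluorophenyl, the size of the step is uncertain, but most of the gain seen in an 8.0-fold lower number from compound 1 to compound 3 (0.91 log units; beyond the scatter) is expected to be lost, so compound 4 is expected to show a 4.9-fold higher number from compound 3 to compound 4 (0.69 log units; beyond the scatter). The estimate for compound 4 in this assay is 400 nM, with a range from 150 nM to 1500 nM.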

Compound 4, half-maximal inhibitory concentration: 370 nM
The estimate for compound 4 lay 1.1-fold (0.03 log units) above the measured number; low and high end bracket the measured number.
By their numbers in this assay, from the lowest: compound 3; then compounds 4 and 1 (each within the scatter of the next). At a limit, above all of these: compound 2.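

In this assay, the step of a 4.5-fold higher number from compound 3 to compound 4 (0.65 log units; beyond the scatter) shows that the gain seen with compound 3 does not extend to every small substituted phenyl group on the sulfonamide nitrogen, as 4-fluorophenyl does not retain it. Fluoro and ethyl on the aromatic carbon cannot be told apart here, since the step of a 1.8-fold lower number from compound 1 to compound 4 (0.25 log units; within the scatter) stays within the usual scatter, so the 3,5-dimethylphenyl group remains the only one of these aryl groups with a clear gain over the others. Fluoro in place of tert-butyl gives an at least 2.7-fold lower number from compound 2 to compound 4 (0.43 log units; beyond the scatter), but this is only a floor and not an exact size because compound 2 stands at a limit: the limit of > 1000 nM in this assay, at which 1 of the 4 values shown sits.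

These numbers cannot tell what makes 3,5-dimethylphenyl better than 4-fluorophenyl, or whether both methyl groups are needed for the gain. On these data alone, it also remains open how a phenyl ring carrying a single methyl group, a methoxy group, a chlorine atom, an amine or a carboxylic acid would behave on this nitrogen.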